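The source may report more compounds than this note shows. Statements on the series, on what has been measured and on what is new or still open speak of the compounds shown alone.

Going by the values given here, compound 2 `O=S(=O)(Nc1ccc(-c2nc3ccccc3o2)cc1)c1cccs1` gives 63000 nM in an assay on cells for inhibition of HSP60/HSP10 (Homo sapiens), with a stated time of 60 min (a higher number here means a weaker inhibitor, a lower number a stronger inhibitor), the highest of the two numbers known. Among the compounds with values here, compound 1 `O=S(=O)(Nc1ccc(-c2nc3cc(NS(=O)(=O)c4cccs4)ccc3o2)cc1)c1cccs1` gives 40000 nM in this assay, and the step of a 1.6-fold higher number from compound 1 to compound 2 (0.20 log units; within the scatter) is the only measured step. Compound 3 `O=S(=O)(Nc1ccc(-c2nc3ccccc3o2)cc1)c1ccc(Cl)c(Cl)c1` differs from compound 2 by 3,4-dichlorophenyl in place of thiophen-2-yl on a sulfonyl sulfur. Within the data shown here, no measured step touches the group on the sulfonyl sulfur, and the one known step lies within the scatter, so for compound 3 a step of no change at the digits printed from compound 2 to compound 3 (within the scatter) is expected, nothing beyond the scatter. Compound 3 is estimated at 63000 nM in this assay, within 20000 nM to 200000 nM.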

Compound 3, half-maximal inhibitory concentration: 25000 nM
Compound 3: the middle estimate sits 2.5-fold (0.40 log units) above what was measured; measured number inside the range.
By their numbers in this assay, from the lowest: compounds 3, 1 and 2 (each within the scatter of the next, the first and the last beyond it).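

Changing the group on the sulfonyl sulfur from thiophen-2-yl to 3,4-dichlorophenyl moves the number in this assay (a 2.5-fold lower number from compound 2 to compound 3 (0.40 log units; beyond the scatter)), so this position responds where the earlier step did not leave the scatter. The step is modest, and compound 3 remains a weak inhibitor in absolute terms. Nothing available explains this step. The compounds shown leave open whether the gain comes from the six-membered ring or from its two chlorines, which plain phenyl would separate. Going by these compounds, how an amine or a carboxylic acid on that ring would read also remains open.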